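Cytotoxicity notes: 4-fluorophenyl in place of 3-methoxyphenyl

The source may hold more compounds than are shown below. What is called first, only, known or untested is meant among the compounds shown, and "the series" means these compounds.

Measured compounds:
compound 1 `COc1cccc(-c2nc3c(c(C)nn3-c3ccccc3)c(-c3ccccc3O)c2C#N)c1` — > 23000 nM
compound 2 `CCc1ccc(-c2nc3c(c(C)nn3-c3ccccc3)c(-c3ccccc3S(C)(=O)=O)c2C#N)cc1` — > 20000 nM
compound 3 `CCc1ccc(-c2nc3c(c(C)nn3-c3ccccc3)c(-c3ccccc3C(F)(F)F)c2C#N)cc1` — > 20000 nM

In an ADME assay on BJ cells (Homo sapiens) for cytotoxicity, with a stated time of 72 h (on this read-out lower numbers stand for an effect already at smaller amounts and higher numbers for an effect only at larger amounts of compound), compound 1 gives > 23000 nM, which is a limit of the assay and not a number. Compound 2 gives > 20000 nM, again a limit. Compound 3 gives > 20000 nM, also a limit. The whole series therefore stands at the top of what this assay resolves: two values sit at the limit of > 20000 nM in this assay, at which 2 of the 3 values shown sit, and one at the limit of > 23000 nM in this assay, at which 1 of the 3 values shown sits. Among the measured compounds shown here, the only step between measured neighbours, a step that the two limits leave unreadable from compound 2 to compound 3, has no readable size, since both ends are limits.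

Compound 4 `Cc1nn(-c2ccccc2)c2nc(-c3ccc(F)cc3)c(C#N)c(-c3ccccc3O)c12` differs from compound 1 by 4-fluorophenyl in place of 3-methoxyphenyl on an aromatic carbon. For the measured compounds named here, no measured step touches this position, so nothing in the data speaks for a step beyond the scatter in this assay, and nothing speaks against one either. The expectation for compound 4 is that it behaves like compound 1, because compound 1 itself sits at the limit of > 23000 nM in this assay, at which 1 of the 3 values shown sits; the step that the limit leaves unreadable from compound 1 to compound 4 is estimated to be flat. Compound 4 is accordingly expected to give about 25000 nM in this assay, within 12000 nM to 60000 nM, most probably reported as a limit rather than a number.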

Compound 4, half-maximal effective concentration: > 20000 nM
Compound 4: only a limit was reported; the forecaster's own chance of this, stated with the estimate: 85%; the middle value does not contradict the limit.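

In this assay compound 4 gives > 20000 nM, a limit and not a number. Compound 1 gives > 23000 nM, also a limit, and the step between these two compounds cannot be read. The compounds shown leave open what size, if any, the change from 3-methoxyphenyl to 4-fluorophenyl has on this read-out.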